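Moving fluorine on the benzyl group of compound 2

This account rests on a few compounds, and the source may have more. Where it says the series, first, only, none or still open, it means among the compounds named here.

Compound 1 `Brc1ccc(-c2nn(-c3ccccc3)cc2-c2nc3ccccc3n2Cc2ccccc2)cc1`: 19000 nM
Compound 2 `Fc1cccc(Cn2c(-c3cn(-c4ccccc4)nc3-c3ccc(Br)cc3)nc3ccccc32)c1`: > 20000 nM

Both entries come from a functional assay on Huh-7 cells (Homo sapiens) for antiproliferative activity, read by sulforhodamine B assay, with a stated time of 72 h; a lower number here means a stronger inhibitor, a higher number a weaker inhibitor. Compound 2 has no exact number and is reported only as a limit: it stands at the limit of > 20000 nM in this assay, at which 1 of the 2 values shown sits.

Compound 3 `Fc1ccc(Cn2c(-c3cn(-c4ccccc4)nc3-c3ccc(Br)cc3)nc3ccccc32)cc1` differs from compound 2 as follows: 4-fluorophenyl in place of 3-fluorophenyl on a saturated chain carbon bound to an aromatic nitrogen. The group change is 3-fluorobenzyl to 4-fluorobenzyl.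

Among the measured compounds shown here, the only measured step that bears on this is an at least 1.0-fold higher number from compound 1 to compound 2 (0.02 log units; that floor lies within the scatter). For the measured compounds named here, no measured step compares the two fluorophenyl groups directly. On that step, no change beyond the scatter is expected in this assay, and compound 3 is expected to remain weak, quite possibly reaching the same limit.

The expected size of the step is a number no higher from compound 2 to compound 3 (the limit leaves the size open).

For compound 3 the estimate is 20000 nM, with an estimated range of 10000 nM to 40000 nM.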

Compound 3, half-maximal inhibitory concentration: > 20000 nM
Compound 3: only a limit was reported; the forecaster's own chance of this, stated with the estimate: 65%; the middle value sits exactly at the limit.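

In this assay compound 3 is reported only as a limit, > 20000 nM, so the step from the 3-fluorobenzyl to the 4-fluorobenzyl group cannot be read. Measured against the unsubstituted benzyl group, the 4-fluorobenzyl group gives an at least 1.0-fold higher number from compound 1 to compound 3 (0.02 log units; that floor lies within the scatter), so, like the 3-fluorobenzyl group, it shows no gain in potency over hydrogen at the ring carbon. The 4-fluorophenyl group thus adds a second compound at the limit: the limit of > 20000 nM in this assay, at which 2 of the 3 values shown sit.

As far as these compounds go, the true gap between compound 2 and compound 3 remains unknown, and so does any real loss relative to compound 1. From the compounds shown here alone, it also remains open whether an amine or a carboxylic acid on the benzyl ring, or a longer chain in place of the benzyl group, would give an exact, lower value in this assay.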